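Dropping the Nitro Group: Expected Effect on Potency

This account rests on a few compounds, and the source may have more. Where it says the series, first, only, none or still open, it means among the compounds named here.

Measured so far in a functional assay on a cell-free system (plasma) for agonist activity at thromboxane A2 receptor (Homo sapiens); a lower number here means a stronger inhibitor, a higher number a weaker inhibitor:
Compound 1, `O=C(O)CCC/C=C1/C[C@H]2C[C@@H](O)[C@H](/C=N/NC(=O)Nc3ccc([N+](=O)[O-])cc3)[C@H]2C1`, gives 50 nM.
Compound 2, `O=C(O)COC/C=C1\C[C@H]2C[C@@H](O)[C@H](/C=N/NC(=O)Nc3ccc(Cl)c(Cl)c3)[C@H]2C1`, gives 180 nM.

Compound 1 has the lowest number of the two; the gap to compound 2 is beyond the usual scatter. Compound 3, `O=C(O)CCC/C=C1/C[C@H]2C[C@@H](O)[C@H](/C=N/NC(=O)Nc3ccccc3)[C@H]2C1`, is not yet measured. It differs from compound 1 in one place: hydrogen in place of nitro on an aromatic carbon. Going by the values given here, no measured pair shows this change on its own, so its size cannot be read from the numbers so far. A modest loss of inhibitory strength is expected, estimated as a 3.0-fold higher number from compound 1 to compound 3 (0.48 log units; beyond the scatter). Compound 3 is accordingly expected to give about 150 nM, within 50 nM to 500 nM.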

Compound 3, half-maximal inhibitory concentration: 100 nM
Compound 3: middle estimate off by 1.5-fold (0.18 log units), on the high side; measured number inside the range.
By their numbers in this assay, from the lowest: compounds 1, 3 and 2 (each within the scatter of the next, the first and the last beyond it).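

Putting hydrogen in place of nitro, on an aromatic carbon para to a large group, gives a 2.0-fold higher number from compound 1 to compound 3 (0.30 log units; within the scatter) in this assay and so leaves the two compounds indistinguishable. At this position, then, the 4-nitrophenyl group can give way to plain phenyl with no change that stands clear of the scatter. No measurement here offers an explanation for this result.

On these data alone, whether an amine or a carboxylic acid at this same position would also match compound 1 stays open. So does whether this swap would give a similar step on a different chain.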